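The compounds below may be only part of what the source reports. "The series", "measured", "known", "first", "only" and "open" are said of these compounds alone.

In a functional assay on RAW264.7 cells (Rattus norvegicus) for inhibition, with RAW264.7 (Mus musculus) as the target, read by Griess assay, with stated times of 2 h and 16 h (on this read-out lower numbers stand for stronger inhibition and higher numbers for weaker inhibition), compound 2 `COc1ccc2c(c1)C(=O)[C@H](O)[C@@H](c1cccc(O)c1O)O2` gives only a limit of the assay, > 100000 nM. Compound 4 `COc1ccc2c(c1)C(=O)[C@@H](O)[C@H](c1cccc(O)c1O)O2` differs from it in that (the two compounds have the same atoms and bonds and differ only in configuration as drawn: 2 of 2 stereo elements differ (all stereocentres are inverted: mirror images); a stereocentre at a saturated ring carbon is drawn R in compound 2 and S in compound 4; a stereocentre at a saturated ring carbon is drawn R in compound 2 and S in compound 4). The nearest measured parallel is the pair of compound 1 `O=C1c2ccccc2O[C@@H](c2cccc(O)c2O)[C@@H]1O` and compound 3 `O=C1c2ccccc2O[C@H](c2cccc(O)c2O)[C@H]1O`, which also differ only in configuration as drawn (the fact that compounds 1 and 3 differ only in the configuration as drawn). In this assay compound 1 gives only a limit, > 100000 nM. In this assay compound 3 likewise gives only a limit, > 100000 nM. The step that the two limits leave unreadable from compound 1 to compound 3 cannot be read, and the step that the two limits leave unreadable from compound 2 to compound 3 is equally unreadable, since every value shown sits at the limit (the limit of > 100000 nM in this assay, at which 3 of the 3 values shown sit). The expected step that the limit leaves unreadable from compound 2 to compound 4 is accordingly none beyond the scatter. Compound 4 is estimated at 150000 nM, with a range of 100000 nM to 300000 nM, most probably reported again only as a limit.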

Compound 4, half-maximal inhibitory concentration: > 100000 nM
Compound 4 was reported as a limit; the forecaster's own chance of this, stated with the estimate: 85%; the middle value lies beyond the limit too.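

Compound 4, like compounds 1, 2 and 3, is reported only as a limit, so neither its step from compound 2 nor its step from compound 1 can be read. The compounds shown leave open whether configuration or the methoxy group makes any difference to inhibition.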